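The source may report more compounds than this note shows. Statements on the series, on what has been measured and on what is new or still open speak of the compounds shown alone.

Working notes on the series. Compound 1, `O=[N+]([O-])c1ccc(-c2nnc(-c3cccnc3)o2)cc1`, gives 73.5 ug/mL in an ADME assay on MT4 cells (Homo sapiens) for cytotoxicity, read by MTT assay, with a stated time of 5 days; a higher number here means that more compound is tolerated, a lower number that less compound is tolerated. Compound 2, `Cc1cccc2sc(NN)nc12`, gives 9.8 ug/mL in this assay. Compound 3, `O=[N+]([O-])c1ccc(-c2nnc(-c3cccnc3)n2Nc2nc3ccc(F)cc3s2)cc1`, is reported in this assay only as a limit, >= 108 ug/mL. Of the three values shown, compound 3 is the single one sitting at the assay boundary, as recorded in the limit of >= 108 ug/mL in this assay, at which 1 of the 3 values shown sits, so no exact figure places it among the others. Compound 4, `O=[N+]([O-])c1ccc(-c2nnc(-c3cccnc3)n2Nc2nc3ccc(Br)cc3s2)cc1`, awaits measurement in this assay. It differs from compound 3 by bromo in place of fluoro on an aromatic carbon, reading one bond further out as 6-fluoro-1,3-benzothiazol-2-yl to 6-bromo-1,3-benzothiazol-2-yl. Among the compounds with values here, no measured pair differing in one place exists here, so no step size can be read from the data. The expected step of an at least 1.1-fold lower number from compound 3 to compound 4 (0.05 log units; that floor lies within the scatter) is none beyond the usual scatter, with a fair chance that only a limit is reported again. Compound 4 is expected to give 95 ug/mL in this assay, within a range of 45 ug/mL to 130 ug/mL.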

Compound 4, half-maximal cytotoxic concentration: 13.2 ug/mL
Compound 4: middle estimate off by 7.2-fold (0.86 log units), on the high side, and the stated range ends above it.
By their numbers in this assay, from the lowest: compounds 2 and 4 (each within the scatter of the next); then compound 1. At a limit, above all of these: compound 3.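

In this assay, within the data shown here, the change from 6-fluoro-1,3-benzothiazol-2-yl to 6-bromo-1,3-benzothiazol-2-yl gives the only single-place comparison so far: an at least 8.1-fold lower number from compound 3 to compound 4 (0.91 log units; beyond the scatter). The aromatic carbon carrying the halogen is therefore not a silent position for tolerance in these cells, as exchanging one halogen for the other moves the number beyond the scatter. Compound 3 stands at a limit, so the step gives only a floor for the size of the change: the limit of >= 108 ug/mL in this assay, at which 1 of the 4 values shown sits.

Open, from the compounds shown here alone, is whether the lower number is particular to bromo, or would also come with chloro, methyl or an amine on the same aromatic carbon. Going by these compounds, with one pair, it also remains open whether the same exchange would carry the same step on another core.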